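The source may hold more compounds than are shown below. What is called first, only, known or untested is meant among the compounds shown, and "the series" means these compounds.

Working notes on the shared core. In an assay on CHO cells for displacement of a labelled ligand from adenosine receptor A3 (Homo sapiens), read by scintillation counting, tested at 10 uM (a higher number here means more inhibition at the concentration tested (going by the name of the read-out), a lower number less inhibition), compound 1 `COc1cccc(-c2sc(N)c(C(=O)c3ccc(Cl)cc3)c2CC(C)(C)C)c1` gives 1%, compound 2 `CC(C)(C)Cc1c(Br)sc(N)c1C(=O)c1cccc(Cl)c1` gives 1%, and compound 3 `CC(C)(C)Cc1c(Br)sc(N)c1C(=O)c1cccc(C(F)(F)F)c1` gives 4%. Compound 3 has the highest of the three numbers, but its gaps to compound 1 and to compound 2 are both within the scatter. Within the data shown here, the only single-point step, a number 3 percentage points higher from compound 2 to compound 3 (within the scatter), is likewise within the scatter. Compound 4 `COc1ccc(-c2sc(N)c(C(=O)c3cccc(C(F)(F)F)c3)c2CC(C)(C)C)cc1` carries 4-methoxyphenyl in place of bromo on an aromatic carbon. Among the measured compounds shown here, no measured step covers this change alone; compound 1 and compound 2, which differ at that position and elsewhere, show the same number, so nothing beyond the scatter is indicated. The step expected from this change is a number 1 percentage points lower from compound 3 to compound 4 (within the scatter). Compound 4 is therefore estimated at 3%, within 0% to 12%.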

Compound 4, a percentage reported as inhibition, at one concentration (the size of the read-out at that concentration, not a potency): 1%
Beside the measured number, compound 4's estimate is 2 percentage points above it; the measured number falls inside the stated range.
By their numbers in this assay, from the lowest: compounds 1, 2, 4 and 3 (each within the scatter of the next).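

In this assay, the position next to the ring sulfur now has a direct comparison in one place: 4-methoxyphenyl in place of bromo gives a number 3 percentage points lower from compound 3 to compound 4 (within the scatter). Replacing bromo with this much larger group, which brings a six-membered aromatic ring, therefore produces no change beyond the scatter. No available evidence bears on this result. As far as these compounds go, whether an amine or a carboxylic acid in place of bromo, or a longer chain in place of the neopentyl group, would move the number beyond the scatter remains open.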